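Acid side chain change from compound 2

A few compounds are considered here, and "the series" means these few. Any claim that something is new, unique, unknown or untested is made for them only; others in the source may bear on it.

Measured so far in a functional assay (plasma) for inhibition, with Homo sapiens as the target; on this read-out higher numbers stand for weaker inhibition and lower numbers for stronger inhibition:
- compound 1 (`O=C(O)Cc1cccc(CC2C3CCC(O3)C2/C=N/NC(=O)Nc2ccccc2)c1`) gives 370 nM
- compound 2 (`O=C(O)COc1ccccc1CC1C2CCC(O2)C1/C=N/NC(=O)Nc1ccccc1`) gives 15 nM

Compound 2 has the lower number of the two, so it is the stronger inhibitor, and the gap to compound 1 lies beyond the scatter. Compound 3 (`O=C(O)CCCc1ccccc1CC1C2CCC(O2)C1/C=N/NC(=O)Nc1ccccc1`) carries 3-carboxypropyl in place of carboxymethoxy on an aromatic carbon. Going by the values given here, no measured step covers this change, so only a moderate rise in this assay towards weaker inhibition is expected (estimated a 2.7-fold higher number from compound 2 to compound 3 (0.43 log units; beyond the scatter)). For compound 3 the estimated value is 40 nM (expected range 10 nM to 200 nM).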

Compound 3, half-maximal inhibitory concentration: 12 nM
Estimate against measurement, compound 3: 3.3-fold (0.52 log units) above; the measured number falls inside the stated range.
By their numbers in this assay, from the lowest: compounds 3 and 2 (each within the scatter of the next); then compound 1.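

In this assay, 3-carboxypropyl in place of carboxymethoxy on this aromatic carbon, ortho to a large group, gives a 1.3-fold lower number from compound 2 to compound 3 (0.10 log units; within the scatter). At this place the two side chains cannot be told apart on this read-out, so the series keeps its standing with either one. Nothing at hand offers an explanation for this result.

Still open, as far as these compounds go, is whether a longer chain such as 4-carboxybutyl or a shorter one such as carboxymethyl holds the same level. From the compounds shown here alone, it is equally open whether a tetrazole or a primary amide can stand in for the carboxylic acid at the chain end.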